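Removing the methoxy group from compound 2

This account rests on a few compounds, and the source may have more. Where it says the series, first, only, none or still open, it means among the compounds named here.

Of the compounds shown here, two have been measured so far in a functional assay on UACC-257 cells (Homo sapiens) for inhibition, read by sulforhodamine B assay, with a stated time of 48 h, tested at 10 uM; a lower number here means less inhibition of growth, a higher number more inhibition of growth at the concentration tested. In this test, compound 1 (`CC(=O)c1ccc(NC(=O)Cn2nc(-c3ccc(Cl)cc3)nc2N)cc1`) gives 19.8% and compound 2 (`COc1ccc(-c2nc3sc(-c4ccccc4)cn3n2)cc1`) gives 28% at the same concentration. These two values lie within the usual scatter of each other, so compound 2 stands level with compound 1 on the numbers available.

Compound 3 (`c1ccc(-c2nc3sc(-c4ccccc4)cn3n2)cc1`) has hydrogen in place of methoxy on an aromatic carbon of compound 2, para to a large group (hydrogen in place of methoxy on an aromatic carbon). Within the data shown here, no measured pair shows what this change does, so the only anchor is compound 2 at 28% in this test. A slight fall is expected, but nothing beyond the scatter: the estimated step is a number 4 percentage points lower from compound 2 to compound 3 (within the scatter) and no more. In this assay the estimate for compound 3 is 24% with an expected range from 8% to 40% at the tested concentration.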

Compound 3, percent growth inhibition at one concentration: 13%
Compound 3: middle estimate off by 11 percentage points, on the high side; measured number inside the range.
By their numbers in this assay, from the lowest: compounds 3, 1 and 2 (each within the scatter of the next, the first and the last beyond it).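

In this assay, among these compounds, the measured pair gives a number 15 percentage points lower from compound 2 to compound 3 (beyond the scatter) when hydrogen takes the place of methoxy on an aromatic carbon, para to a large group, and this is the first measured step that changes one place only. It shows that the group at this position matters in this test: with the rest of the structure unchanged, the compound carrying methoxy inhibits growth more at the tested concentration, though the step is modest. No measurement shown here accounts for the difference.

Going by these compounds, whether another group at this position, such as an amine, a carboxylic acid or a longer chain like ethoxy, would give a higher or lower number remains open. A single pair also cannot show whether the same change would act similarly on a different core.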